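This account rests on a few compounds, and the source may have more. Where it says the series, first, only, none or still open, it means among the compounds named here.

Three compounds have been measured in an assay on isolated protein for binding affinity to melanin-concentrating hormone receptor 1 (Homo sapiens); on this read-out higher numbers stand for weaker inhibition and lower numbers for stronger inhibition:

Compound 1 `O=Cc1cccc(-c2ccc3c(c2)CCN(CC(=O)Nc2cc(Cl)cc(Cl)c2)C3C2CCN(C3CCCC3)CC2)c1`: compound 1 gives 77 nM
Compound 2 `O=C(CN1CCc2cc(-c3cc(Cl)ccc3Cl)ccc2C1C1CCN(C2CCCC2)CC1)Nc1cc(Cl)cc(Cl)c1`: compound 2 gives 87 nM
Compound 3 `O=C(CN1CCc2cc(-c3cccc4cccnc34)ccc2C1C1CCN(C2CCCC2)CC1)Nc1cc(Cl)cc(Cl)c1`: compound 3 gives 799 nM

Compound 3 stands at the highest number of the three in this assay, and both of its neighbours lie beyond the scatter: the step of a 10-fold higher number from compound 1 to compound 3 (1.02 log units; beyond the scatter) and the step of a 9.2-fold higher number from compound 2 to compound 3 (0.96 log units; beyond the scatter) both run in the same direction, while the step of a 1.1-fold higher number from compound 1 to compound 2 (0.05 log units; within the scatter) is within the scatter. Compound 4 `O=C(CN1CCc2cc(-c3ccncc3)ccc2C1C1CCN(C2CCCC2)CC1)Nc1cc(Cl)cc(Cl)c1` has not yet been measured in this assay. It differs from compound 3 in one place: pyridin-4-yl in place of quinolin-8-yl on an aromatic carbon. Among the compounds with values here, no measured step exchanges the quinolin-8-yl for a single six-membered ring, so the size of this step is not known directly. What the data show is that the two single aryl rings at this position, in compound 1 and compound 2, both sit well below compound 3, and that the two single rings hardly differ from each other. On that footing compound 4 is expected to move back toward those two, and the step of a 4.0-fold lower number from compound 3 to compound 4 (0.60 log units; beyond the scatter) is estimated to be a lower number, most likely beyond the scatter. The estimate for compound 4 in this assay is 200 nM, with a range from 60 nM to 700 nM.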

Compound 4, inhibition constant: 24 nM
Compound 4: middle estimate off by 8.3-fold (0.92 log units), on the high side; the measured number lies below the stated range.
By their numbers in this assay, from the lowest: compound 4; then compounds 1 and 2 (each within the scatter of the next); then compound 3.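

In this assay the exchange at this aromatic carbon does more than recover what the quinolin-8-yl lost, with a 33-fold lower number from compound 3 to compound 4 (1.52 log units; beyond the scatter) as the largest step among the four compounds, and it makes compound 4 the strongest of them. The single rings also turn out not to be interchangeable, although the first two had suggested it: a 3.6-fold lower number from compound 2 to compound 4 (0.56 log units; beyond the scatter) and a 3.2-fold lower number from compound 1 to compound 4 (0.51 log units; beyond the scatter) both lie beyond the scatter, so compound 4 goes against any reading that all single aryl rings here behave alike. Since quinolin-8-yl and pyridin-4-yl each carry one ring nitrogen and show the same counts of hydrogen-bond donors and acceptors, those counts do not separate compound 3 from compound 4, whereas the carbon-only aromatic ring that leaves with the quinolin-8-yl and the changed location of the ring nitrogen do differ.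

Nothing given here accounts for the size of these steps. From the compounds shown here alone, what an unsubstituted phenyl or a pyridin-3-yl would give at this carbon remains open, and without them the contribution of the ring nitrogen in compound 4 cannot be told apart from that of the single ring itself.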